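Uracil amide series: chloroacetamide analogue of compound 2

This account rests on a few compounds, and the source may have more. Where it says the series, first, only, none or still open, it means among the compounds named here.

compound 1, `Cn1cc(CO)c(N)nc1=O`: > 100000 nM
compound 2, `NCC(=O)Nc1c[nH]c(=O)[nH]c1=O`: > 100000 nM

In a functional assay on SW-620 cells (Homo sapiens) for inhibition, read by MTT assay, with a stated time of 72 h (a lower number here means a stronger inhibitor, a higher number a weaker inhibitor), compound 1 gives only the limit > 100000 nM. In this assay compound 2 likewise gives only the limit > 100000 nM. Compound 2 sits at the limit of > 100000 nM in this assay, at which 2 of the 2 values shown sit. Compound 3, `O=C(CCl)Nc1c[nH]c(=O)[nH]c1=O`, differs from compound 2 by chloro in place of amino on a saturated chain carbon bound to a carbonyl carbon. Within the data shown here, no step between measured compounds exists to anchor this change. Starting from a limit, the step of an at least 1.2-fold lower number from compound 2 to compound 3 (0.09 log units; that floor lies within the scatter) is expected to be small or absent beyond the scatter, with some chance of a measurable number. Compound 3 is therefore estimated at 80000 nM, range 8000 nM to 300000 nM.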

Compound 3, half-maximal inhibitory concentration: 12000 nM
Beside the measured number, compound 3's estimate is 6.7-fold (0.82 log units) above it; low and high end bracket the measured number.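

Chloro in place of amino on a saturated chain carbon bound to a carbonyl carbon gives an at least 8.3-fold lower number from compound 2 to compound 3 (0.92 log units; beyond the scatter) in this assay, the first readable step in the series. Compound 3 is also the first compound shown with a measured number rather than a limit, so activity in this assay responds to the group at this position. The step remains a floor, since compound 2 stands at a limit: the limit of > 100000 nM in this assay, at which 2 of the 3 values shown sit.

The compounds shown leave open whether bromo, hydroxy or a longer chain carrying chloro at this position would give a number as low as that of compound 3.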